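Para-substituent swap on the phenyl arm of the series

This account rests on a few compounds, and the source may have more. Where it says the series, first, only, none or still open, it means among the compounds named here.

The shared core carries a 4-substituted phenyl group next to a pyridine; compound 1 `Cc1ccc(C(CC/N=C(\N)NCCCc2c[nH]cn2)c2ccccn2)cc1` bears a methyl there, compound 2 `COc1ccc(C(CC/N=C(\N)NCCCc2c[nH]cn2)c2ccccn2)cc1` a methoxy, and compound 3 `N=C(NCCCc1c[nH]cn1)NCCC(c1ccc(F)cc1)c1ccccn1` a fluoro. In a functional assay on muscle tissue for agonist activity at histamine H2 receptor (Cavia porcellus) (on this read-out higher numbers stand for higher potency (the scale is a negative logarithm) and lower numbers for lower potency), compound 1 gives 7.15, compound 2 gives 7, and compound 3 gives 7.94. The step of a number 0.15 log units lower from compound 1 to compound 2 (within the scatter) is within the scatter. Compound 3 stands highest of the three numbers, with compound 1 the nearest and compound 2 the furthest, both gaps beyond the scatter.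

Compound 4 `N=C(NCCCc1c[nH]cn1)NCCC(c1ccc(Br)cc1)c1ccccn1` follows from compound 3 by the change (bromo in place of fluoro on an aromatic carbon). Within the data shown here, no measured step in this set exchanges one halogen for another, so the only guidance is indirect: the methyl-to-methoxy step is flat, while fluoro sits above both of those groups. Bromo is neither of these, and its effect is not covered by any pair shown. A step of moderate size in this assay is therefore plausible in either direction, with a downward lean toward the methyl and methoxy numbers because compound 3 at 7.94 is the outlier of the set. The expected step from compound 3 to compound 4 is a number 0.44 log units lower from compound 3 to compound 4 (beyond the scatter). Compound 4 is estimated at 7.5, within 6.9 to 8.1.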

Compound 4, negative logarithm of the half-maximal effective concentration: 6.97
Estimate against measurement, compound 4: 0.53 log units above; low and high end bracket the measured number.
By their numbers in this assay, from the lowest: compounds 4, 2 and 1 (each within the scatter of the next); then compound 3.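

In this assay bromo in place of fluoro on an aromatic carbon para to a large group gives a number 0.97 log units lower from compound 3 to compound 4 (beyond the scatter), so this position responds strongly to an exchange of one halogen for another, in contrast to the flat a number 0.15 log units lower from compound 1 to compound 2 (within the scatter). Compound 1 at 7.15, compound 2 at 7 and compound 4 at 6.97 lie within the scatter of each other, which leaves the 4-fluorophenyl of compound 3 alone above the other three and shows that a halogen at this place does not by itself carry the higher number, with compound 4 the case against such a reading. The data at hand offer no explanation for the gap between fluoro and bromo.

As far as these compounds go, whether chloro or a plain unsubstituted phenyl would stand with fluoro or with the other three groups remains open. The same holds for an amine or a carboxylic acid on this aromatic carbon, and for whether the fluoro result carries over to other places on the ring.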